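Methyl in place of hydroxyethyl on a xanthine-type core

This account rests on a few compounds, and the source may have more. Where it says the series, first, only, none or still open, it means among the compounds named here.

Compound 2 `CCCn1c(=O)n(CCO)c(=O)c2[nH]cnc21` gives the lowest number of the two compounds measured in a functional assay (trachea) with Cavia porcellus as the target (on this read-out lower numbers stand for an effect already at smaller amounts and higher numbers for an effect only at larger amounts of compound), at 510 nM; compound 1 `CCCn1c(=O)n(CC(=O)O)c(=O)c2[nH]cnc21` gives 41000 nM. Going by the values given here, the only measured step, an 80-fold lower number from compound 1 to compound 2 (1.91 log units; beyond the scatter), changed the same position. Compound 3 `CCCn1c(=O)n(C)c(=O)c2[nH]cnc21` differs from compound 2 as follows: hydrogen in place of hydroxymethyl on a saturated chain carbon bound to an aromatic nitrogen. Among the compounds with values here, no measured step removes the group entirely, so the bearing of the earlier step is indirect. Compound 3 is therefore expected to give a somewhat higher number, a 2.9-fold higher number from compound 2 to compound 3 (0.47 log units; beyond the scatter), and its value is estimated at 1500 nM, within 400 nM to 6000 nM.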

Compound 3, half-maximal effective concentration: 1600 nM
Compound 3: the middle estimate sits 1.1-fold (0.03 log units) below what was measured; low and high end bracket the measured number.
By their numbers in this assay, from the lowest: compound 2; then compound 3; then compound 1.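

In this assay, the change from 2-hydroxyethyl to methyl gives a 3.1-fold higher number from compound 2 to compound 3 (0.50 log units; beyond the scatter), while replacing the carboxy group with hydrogen gives a 26-fold lower number from compound 1 to compound 3 (1.41 log units; beyond the scatter). Compound 3 thus provides a reference at this position: among these compounds, the hydroxymethyl group goes with a lower number and the carboxy group with a much higher one. No supporting evidence is available to explain either step.

From the compounds shown here alone, it remains open whether an amine or a longer chain ending in hydroxyl at this position would give a number below that of compound 2.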